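The source may hold more compounds than are shown below. What is called first, only, known or untested is meant among the compounds shown, and "the series" means these compounds.

Measured compounds:
Compound 1, `COc1cc(/C=C2\CN(C)C/C(=C\c3cc(OC)c(OC)c(OC)c3)C2=O)cc(OC)c1OC`, gives 1000 nM in a functional assay on NCI-H460 cells (Homo sapiens) for cytotoxicity, read by MTT assay, with a stated time of 72 h; a lower number here means a stronger inhibitor, a higher number a weaker inhibitor.
Compound 2, `CCN1C/C(=C\c2cc(OC)c(OC)c(OC)c2)C(=O)/C(=C/c2cc(OC)c(OC)c(OC)c2)C1`, gives 4900 nM in this assay.

Among the compounds with values here, compound 2 has the highest of the two numbers in this assay; its nearest neighbour is compound 1, and the only measured step, a 4.9-fold higher number from compound 1 to compound 2 (0.69 log units; beyond the scatter), is a modest one beyond the scatter. Compound 3, `COc1cc(/C=C2\CN(C(=O)CCC(=O)O)C/C(=C\c3cc(OC)c(OC)c(OC)c3)C2=O)cc(OC)c1OC`, is not yet measured. It differs from compound 2 in one place: (2-carboxyethyl)carbonyl in place of ethyl on an amine nitrogen in a ring. Within the data shown here, the single measured step concerns a small change of the same group, so it bears only loosely on this larger exchange and offers no clear direction. Compound 3 is therefore expected to lie near compound 2, with a 1.2-fold higher number from compound 2 to compound 3 (0.09 log units; within the scatter) not clearly beyond the scatter. The estimate for compound 3 in this assay is 6000 nM, within a range of 1200 nM to 30000 nM.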

Compound 3, half-maximal inhibitory concentration: > 60000 nM
Compound 3: only a limit was reported (the forecaster's own chance of this, stated with the estimate: 10%); middle value at least 10-fold (1.00 log units) away from the limit.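

Compound 3 is reported in this assay only as a limit: the limit of > 60000 nM in this assay, at which 1 of the 3 values shown sits. Even so, the amine nitrogen in the ring proves far more sensitive to this exchange than the earlier pair could show: (2-carboxyethyl)carbonyl in place of ethyl gives an at least 12-fold higher number from compound 2 to compound 3 (1.08 log units; beyond the scatter), and the same group in place of methyl gives an at least 60-fold higher number from compound 1 to compound 3 (1.77 log units; beyond the scatter). Both steps are large, whereas going from methyl to ethyl at this nitrogen gave only the modest 4.9-fold higher number from compound 1 to compound 2 (0.69 log units; beyond the scatter).

The compounds shown leave open whether the loss follows the carbonyl on the nitrogen, the carboxylic acid at the end of the chain, or the length of the chain. A simple acetyl, a methyl ester of the acid, or a longer alkyl chain at this nitrogen would tell these apart.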